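This account rests on a few compounds, and the source may have more. Where it says the series, first, only, none or still open, it means among the compounds named here.

The study turns on a shared core, seen in compound 1 `CCOC(=O)c1cnc(-c2ccccc2F)[nH]c1=O`, compound 2 `CCOC(=O)c1cnc(-c2ccccc2[N+](=O)[O-])[nH]c1=O` and compound 3 `CCOC(=O)c1cnc(-c2ccccc2N)[nH]c1=O`, which differ only in the group on the phenyl ring. In a functional assay on the whole organism (strain Sprague-Dawley) for inhibition, with Rattus norvegicus as the target, with a stated time of 10 min (on this read-out lower numbers stand for an effect already at smaller amounts and higher numbers for an effect only at larger amounts of compound), compound 1 gives > 10 mg/kg, which is a limit of the assay and not a number. Compound 2 gives "not determined" (no result reported) in this assay. Compound 3 also gives "not determined" (no result reported) in this assay, so no single number fixes where compound 3 stands. Among the measured compounds shown here, of the other two entries, that of compound 2 has no number and that of compound 1 is a limit of the assay, and the only reading available is the limit of > 10 mg/kg in this assay, at which 1 of the 3 values shown sits. Compound 4 `CCOC(=O)c1cnc(-c2ccccc2OC)[nH]c1=O` is the next member. It differs from compound 3 by methoxy in place of amino on an aromatic carbon. For the measured compounds named here, with no measured step between any two compounds, no direction for the change from compound 3 to compound 4 can be read from the data, and the step is expected to stay within the usual scatter. Compound 4 is therefore estimated to reach 15 mg/kg in this assay, within a range of 4 mg/kg to 60 mg/kg.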

Compound 4, dose for 50% inhibition: 10 mg/kg
Beside the measured number, compound 4's estimate is 1.5-fold (0.18 log units) above it; measured number inside the range.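

In this assay compound 4 gives 10 mg/kg, the only single number among the compounds shown, so this aromatic carbon now has one firm reading with a methoxy group on it. Methoxy in place of fluoro gives a number no higher from compound 1 to compound 4 (the limit leaves the size open), so the change does not raise the number, while the size of any drop stays unknown. Among the compounds shown here, compound 1 supplies a limit of the assay and not a number, and this is the only other reading for the position: the limit of > 10 mg/kg in this assay, at which 1 of the 4 values shown sits.

How methoxy stands against amino or nitro on this aromatic carbon remains unread. Also open, as far as these compounds go, is whether a longer chain such as ethoxy, or a carboxylic acid, in the same place would give a lower number than compound 4.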